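The source may report more compounds than this note shows. Statements on the series, on what has been measured and on what is new or still open speak of the compounds shown alone.

Compound 1 `COc1nc(N)nc2c1c(-c1ccccc1)cn2[C@@H]1O[C@H](CO)[C@@H](O)[C@H]1O` and compound 2 `COc1nc(N)nc2c1c(-c1cccs1)cn2[C@@H]1O[C@H](CO)[C@@H](O)[C@H]1O` share one core, while compound 3 `CNc1ncnc2c1c(-c1ccccc1)cn2[C@@H]1O[C@H](CO)[C@@H](O)[C@H]1O` is built on another; how the two cores differ is not broken down here. In a functional assay on HepG2 cells (Homo sapiens) for antiproliferative activity, read by XTT assay, with a stated time of 72 h (a higher number here means a weaker inhibitor, a lower number a stronger inhibitor), compound 1 gives only a limit of the assay, > 20000 nM. In this assay compound 2 likewise gives only a limit, > 20000 nM. In this assay compound 3 also gives only a limit, > 20000 nM. The change from compound 1 to compound 2 is thiophen-2-yl in place of phenyl on an aromatic carbon, and its size is a step that the two limits leave unreadable from compound 1 to compound 2. Compound 4 `CNc1ncnc2c1c(-c1cccs1)cn2[C@@H]1O[C@H](CO)[C@@H](O)[C@H]1O`, not yet measured, arises from compound 3 by the same kind of change, (thiophen-2-yl in place of phenyl on an aromatic carbon); around the place the neighbouring group is once described as a 3,4-dihydroxy-5-(hydroxymethyl)oxolan-2-yl group (9 heavy atoms) and once simply as a group of 9 heavy atoms. Because the limit of > 20000 nM in this assay, at which 3 of the 3 values shown sit, shows every measured value resting at that limit, the step from compound 3 to compound 4 is expected to be a step that the limit leaves unreadable from compound 3 to compound 4 in this assay. Compound 4 is thus estimated to give about 30000 nM in this assay, with a likely range from 10000 nM to 100000 nM, most probably reported again only as a limit.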

Compound 4, half-maximal inhibitory concentration: > 20000 nM
Compound 4: a limit, no number (the forecaster's own chance of this, stated with the estimate: 85%); the middle value is on the limit's open side.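

In this assay compound 4 gives > 20000 nM as a limit of the assay, not a number. For the compounds shown here, compound 3 also gives only a limit, so no step between compound 3 and compound 4 can be read. With no number among them, the compounds shown leave open whether thiophen-2-yl in place of phenyl changes antiproliferative activity at all.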